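A few compounds are considered here, and "the series" means these few. Any claim that something is new, unique, unknown or untested is made for them only; others in the source may bear on it.

Compound 2 `Oc1ccc(-n2cc(-c3ccc4ccccc4n3)nn2)cc1` stands lowest of the three numbers in hand in a physicochemical assay for solubility, read by spectrophotometry, using the shake flask method, with a stated time of 2 days, at pH 6.5 (a higher number here means a more soluble compound, a lower number a less soluble compound), giving 2.2 ug/mL. Compound 1 `O=C(O)c1cccc(Oc2cccc3nc(-c4cn(-c5ccc(O)c(F)c5)nn4)ccc23)c1` gives 47.2 ug/mL in this assay, and compound 3 `O=C(O)COCCOc1ccc2nc(-c3cn(-c4ccc(O)c(F)c4)nn3)ccc2c1` gives 867 ug/mL; each of those two lies beyond the scatter above compound 2, compound 3 by the wider margin. Compound 4 `OCCOc1ccc2nc(-c3cn(-c4ccc(O)cc4)nn3)ccc2c1` has not yet been measured. It differs from compound 2 in a single place: 2-hydroxyethoxy in place of hydrogen on an aromatic carbon. No pair of measured compounds differs in one place only, so no measured step bears directly on this change, and the account can lean only on the three numbers shown. Compound 3, which carries a longer chain on its core, holds the highest value of the set. Against that background compound 4 is expected to show a rise of a 6.8-fold higher number from compound 2 to compound 4 (0.83 log units; beyond the scatter) in this assay. The value of compound 4 is estimated at 15 ug/mL, with a range from 4 ug/mL to 60 ug/mL.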

Compound 4, solubility: 2.6 ug/mL
Beside the measured number, compound 4's estimate is 5.8-fold (0.76 log units) above it, outside the stated range (below it).
By their numbers in this assay, from the lowest: compounds 2 and 4 (each within the scatter of the next); then compound 1; then compound 3.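

Within the data shown here, the one step at this position shows that 2-hydroxyethoxy in place of hydrogen on an aromatic carbon of the fused system gives a 1.2-fold higher number from compound 2 to compound 4 (0.07 log units; within the scatter) in this assay, so compound 2 and compound 4 cannot be told apart by this read-out. On the shared core of this pair, then, a chain of 4 heavy atoms with no net charge at this position leaves the two numbers within the usual scatter of each other. No separate measurement accompanies this pair to account for that result.

The compounds shown leave open whether a carboxylic acid at the end of a longer chain, or an amine, at this same position would take the number beyond the scatter of compound 2. They also leave open whether the step from hydrogen to 2-hydroxyethoxy would read the same on another core.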